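This account rests on a few compounds, and the source may have more. Where it says the series, first, only, none or still open, it means among the compounds named here.

Compound 1 `CCCN(Cc1sc(Nc2c(C)cc(C)cc2Br)nc1C(F)(F)F)CC1CC1` and compound 2 `CCCN(Cc1sc(Nc2c(Cl)cc(C(F)(F)F)cc2Cl)nc1C(F)(F)F)CC1CC1` share one core and differ in the substituted benzene ring attached through the amine. In an assay for displacement of a labelled ligand from corticotropin-releasing factor receptor 1 (Homo sapiens) (on this read-out lower numbers stand for stronger inhibition and higher numbers for weaker inhibition), compound 1 gives 21 nM, the lowest of the two numbers, and in this assay compound 2 gives 28 nM; the two values lie within the usual scatter of each other, so nothing separates them. Compound 3 `CCCN(Cc1sc(Nc2c(C)cc(C)cc2C)nc1C(F)(F)F)CC1CC1` differs from compound 1 by methyl in place of bromo on an aromatic carbon. Among the compounds with values here, no measured pair shows this change, so only a small step is expected, a 1.4-fold higher number from compound 1 to compound 3 (0.15 log units; within the scatter). Compound 3 is estimated at 30 nM, between 10 nM and 100 nM.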

Compound 3, inhibition constant: 60 nM
Beside the measured number, compound 3's estimate is 2.0-fold (0.30 log units) below it, and the stated range covers the measured number.
By their numbers in this assay, from the lowest: compounds 1 and 2 (each within the scatter of the next); then compound 3.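

Replacing bromo with methyl on this aromatic carbon gives a 2.9-fold higher number from compound 1 to compound 3 (0.46 log units; beyond the scatter) in this assay, so this position responds to the change even though each group counts as one heavy atom with no hydrogen-bond donors or acceptors. Within the data shown here, this is the first single-place comparison available, and the step is modest. Nothing measured here explains it.

As far as these compounds go, whether a methoxy group, an amine or fluoro in this place would give a number closer to compound 1 or to compound 3 remains open. Whether the same swap gives a similar step elsewhere on the benzene ring is also unknown.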